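The compounds below may be only part of what the source reports. "The series", "measured", "known", "first", "only" and "open" are said of these compounds alone.

Measured so far in an assay on mitochondria for inhibition of Amine oxidase [flavin-containing] A (Rattus norvegicus); a higher number here means a weaker inhibitor, a lower number a stronger inhibitor:
compound 1, `NC(=O)[C@H](CO)NCc1ccc(OCc2cccc(Cl)c2)cc1` — 84600 nM
compound 2, `NC(=O)[C@H](CO)NCc1ccc(OCc2cccc(F)c2)cc1` — 100000 nM
compound 3, `NC(=O)CNCc1ccc(OCc2ccc([N+](=O)[O-])cc2)cc1` — 21200 nM

Compound 1 holds the second highest of the three numbers in this assay. Within the data shown here, its nearest neighbour is compound 2, and the only step between compounds differing in one place is a 1.2-fold higher number from compound 1 to compound 2 (0.07 log units; within the scatter), which shows that swapping the halogen on the aromatic carbon leaves the reading essentially where it was. Compound 3 sits furthest from compound 1, with a lower number that lies beyond the scatter, but compound 3 differs in more than one place, so that gap cannot be tied to a single change.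

The compound now in question is compound 4, `NC(=O)[C@@H](CO)NCc1ccc(OCc2cccc(Cl)c2)cc1`. Relative to compound 1 the change is the two compounds have the same atoms and bonds and differ only in configuration as drawn: 1 of 1 stereo elements differ; a stereocentre at a saturated chain carbon is drawn S in compound 1 and R in compound 4. Among the measured compounds shown here, no measured pair here differs only in configuration, so the data give no step that bears on this change in either direction. Compound 4 is therefore expected to land close to compound 1, the step of no change at the digits printed from compound 1 to compound 4 (within the scatter) being set to nothing beyond the scatter, while the range is kept wide. The estimate for compound 4 in this assay is 84600 nM, within 20000 nM to 300000 nM.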

Compound 4, half-maximal inhibitory concentration: 100000 nM
The estimate for compound 4 lay 1.2-fold (0.07 log units) below the measured number; measured number inside the range.
By their numbers in this assay, from the lowest: compound 3; then compounds 1, 2 and 4 (each within the scatter of the next).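

In this assay, among these compounds, the stereocentre at the saturated chain carbon now has a step of its own, a 1.2-fold higher number from compound 1 to compound 4 (0.07 log units; within the scatter), whereas the earlier compounds offered only a change of halogen. This step can be read on that single stereocentre, because no other difference separates the pair: the fact that compounds 1 and 4 differ only in the configuration as drawn. With the chloro group in place, drawing this centre S or R therefore leaves the reading within the scatter, and the same holds for the halogen swap, a 1.2-fold higher number from compound 1 to compound 2 (0.07 log units; within the scatter), so neither single change shown moves the number beyond the scatter.

The compounds shown leave open whether configuration at this carbon would count for as little with another group on the aromatic carbon, such as a methoxy group, or with the hydroxymethyl group replaced by a longer chain. They also leave open what a carboxylic acid in place of the primary amide would do to the reading, and compound 3, which lacks the hydroxymethyl group, differs from the others in more than one place and cannot settle the role of that group.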